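A few compounds are considered here, and "the series" means these few. Any claim that something is new, unique, unknown or untested is made for them only; others in the source may bear on it.

Working notes on the series.

Compound 3 `O=C(c1ccccc1)N1CCC(NCCSC(c2ccc(F)cc2)c2ccc(F)cc2)CC1` gives 4.51 nM in an assay on membranes from striatum (strain Sprague-Dawley) for displacement of a labelled ligand from sodium-dependent dopamine transporter (Rattus norvegicus), read by scintillation counting, with a stated time of 120 min; on this read-out higher numbers stand for weaker inhibition and lower numbers for stronger inhibition. Among the measured compounds shown here, that is the lowest number of the three measured so far: compound 1 `Fc1ccc(C(SCCNC2CCN(Cc3ccc(Cl)cc3)CC2)c2ccc(F)cc2)cc1` gives 39.6 nM and compound 2 `OC(Cc1ccccc1)CN1CCC(NCCSC(c2ccc(F)cc2)c2ccc(F)cc2)CC1` gives 31.4 nM, with a 1.3-fold lower number from compound 1 to compound 2 (0.10 log units; within the scatter) between them. Both arylmethyl-bearing compounds sit above compound 3: an 8.8-fold lower number from compound 1 to compound 3 (0.94 log units; beyond the scatter) and a 7.0-fold lower number from compound 2 to compound 3 (0.84 log units; beyond the scatter).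

Compound 4 `Fc1ccc(C(SCCNC2CCN(Cc3cc4ccccc4o3)CC2)c2ccc(F)cc2)cc1` differs from compound 3 by (1-benzofuran-2-yl)methyl in place of benzoyl on an amine nitrogen in a ring. This change brings the series back from a benzoyl on the ring nitrogen to a methylene-linked aromatic group, which is the direction opposite to the steps of an 8.8-fold lower number from compound 1 to compound 3 (0.94 log units; beyond the scatter) and a 7.0-fold lower number from compound 2 to compound 3 (0.84 log units; beyond the scatter). Those two steps are the only ones that bear on the change, and both were modest and beyond the scatter. For the measured compounds named here, a step upward in this assay of comparable size is therefore expected, roughly undoing the gain seen for the benzoyl; the benzofuranylmethyl has no measured counterpart, so the size is uncertain.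

Compound 4 is expected at 28 nM, with a range of 9 nM to 90 nM, meaning an estimated step of a 6.2-fold higher number from compound 3 to compound 4 (0.79 log units; beyond the scatter).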

Compound 4, inhibition constant: 120 nM
Compound 4: the middle estimate sits 4.3-fold (0.63 log units) below what was measured, and the stated range ends below it.
By their numbers in this assay, from the lowest: compound 3; then compounds 2 and 1 (each within the scatter of the next); then compound 4.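

Placing (1-benzofuran-2-yl)methyl on the amine nitrogen in a ring in place of benzoyl, in this assay, gives the largest step seen so far (a step of a 27-fold higher number from compound 3 to compound 4 (1.43 log units; beyond the scatter)), so this position can shift the number by more than the earlier benzoyl comparisons showed. Groups joined through a saturated carbon at this nitrogen also do not all read alike (steps of a 3.8-fold higher number from compound 2 to compound 4 (0.58 log units; beyond the scatter) and a 3.0-fold higher number from compound 1 to compound 4 (0.48 log units; beyond the scatter)), which leaves compound 4 the weakest of the four in this assay. No measurement shown bears on the cause of these steps.

Still open, as far as these compounds go, is whether the low number of compound 3 follows the carbonyl or the phenyl ring. A 1-benzofuran-2-carbonyl group and an unsubstituted benzyl group on the same nitrogen would separate the two.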